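The compounds below may be only part of what the source reports. "The series", "measured", "known", "first", "only" and "open" are said of these compounds alone.

Three compounds of the shared core have been run in a functional assay on COLO 205 cells (Homo sapiens) for inhibition, read by sulforhodamine B assay, with a stated time of 48 h; on this read-out higher numbers stand for weaker inhibition of growth and lower numbers for stronger inhibition of growth. Compound 1 `CCOC(=O)[C@H](CCC(=O)O)NC(=O)c1ccc(CNc2nc3cc(N)cc(N)c3nc2-c2ccccc2)cc1` gives 19500 nM in this assay. Compound 2 `Nc1cc(N)c2nc(-c3ccccc3)c(NCc3ccc(Cl)c(Cl)c3)nc2c1` gives 17000 nM in this assay. Compound 3 `CCOC(=O)[C@H](CCC(=O)O)NC(=O)c1ccc(Sc2nc3cc(N)cc(N)c3nc2-c2ccccc2)cc1` gives 28200 nM in this assay. The three numbers sit close together: the gap from compound 2 to compound 1 and the gap from compound 2 to compound 3 both fall within the usual scatter of repeated measurements, so none of the three can be set apart from the others on this assay.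

Compound 4 `COc1ccc(CNc2nc3cc(N)cc(N)c3nc2-c2ccccc2)cc1` has not yet been run. It differs from compound 2 in one place: 4-methoxyphenyl in place of 3,4-dichlorophenyl on a saturated chain carbon bound to a nitrogen on an aromatic ring. Among the compounds with values here, no measured pair in the set carries this change, so there is no step to lean on. Given that all three measured values sit in one band, the change is expected to move this assay little, if at all beyond the scatter, with weak inhibition of growth remaining. The expected step of a 1.5-fold higher number from compound 2 to compound 4 (0.17 log units; within the scatter) is small. Compound 4 is estimated at 25000 nM in this assay, within a range from 8000 nM to 80000 nM.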

Compound 4, concentration for 50% growth inhibition: 15500 nM
Estimate against measurement, compound 4: 1.6-fold (0.21 log units) above; the measured number falls inside the stated range.
By their numbers in this assay, from the lowest: compounds 4, 2, 1 and 3 (each within the scatter of the next).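

In this assay, 4-methoxyphenyl in place of 3,4-dichlorophenyl on a saturated chain carbon bound to a nitrogen on an aromatic ring gives a 1.1-fold lower number from compound 2 to compound 4 (0.04 log units; within the scatter), the first step read at this position. The entering group carries a hydrogen-bond acceptor that the leaving group lacks, and the loss of both chlorines comes with it, yet this difference does not set the two compounds apart on this read-out. No measurement is available that would explain this result.

Going by these compounds, whether a carboxylic acid or an amine on that phenyl ring, or a longer chain in place of the saturated chain carbon, would move the number beyond the scatter stays open. A single step also leaves open whether an unsubstituted phenyl would fall in the same band.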